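Replacing the large nitrogen substituent of compound 3 with ethyl

A few compounds are considered here, and "the series" means these few. Any claim that something is new, unique, unknown or untested is made for them only; others in the source may bear on it.

In a functional assay on LNCaP cells (Homo sapiens) for cytotoxicity (on this read-out higher numbers stand for weaker inhibition and lower numbers for stronger inhibition), compound 3 `CNC(=O)Nc1ccc(-c2nc(N3CC4CCC(C3)O4)c3cnn(C4CCC5(CC4)OCCCO5)c3n2)cc1` gives 8 nM and holds the lowest of the three numbers. Compound 1 `CNC(=O)Nc1ccc(-c2nc(N3CC4CCC(C3)O4)c3cnn(C)c3n2)cc1` gives 170 nM and compound 2 `CNC(=O)Nc1ccc(-c2nc(N3CC4CCC(C3)O4)c3cnn(CCN(C)C)c3n2)cc1` gives 400 nM on the same read-out. Among the measured compounds shown here, compound 4 `CCn1ncc2c(N3CC4CCC(C3)O4)nc(-c3ccc(NC(=O)NC)cc3)nc21` carries a group of 2 heavy atoms (2 carbon; no ring) in place of a group of 11 heavy atoms (9 carbon, 2 oxygen; one six-membered non-aromatic ring of carbon only, one six-membered non-aromatic ring with 2 hetero atoms), on an aromatic nitrogen as its only change from compound 3. For the measured compounds named here, two steps bear on this: a 21-fold lower number from compound 1 to compound 3 (1.33 log units; beyond the scatter) and a 50-fold lower number from compound 2 to compound 3 (1.70 log units; beyond the scatter) are both large, and both bring in the group that compound 4 loses. The single carbon atom on that nitrogen in compound 1 with 170 nM is the nearest match to ethyl, so most of that drop should be undone. A large upward step of a 15-fold higher number from compound 3 to compound 4 (1.18 log units; beyond the scatter) is expected in this assay for this change. The estimate for compound 4 is 120 nM with an expected range of 40 nM to 350 nM for this measurement.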

Compound 4, half-maximal inhibitory concentration: 70 nM
Estimate against measurement, compound 4: 1.7-fold (0.23 log units) above, within the range that was stated.
By their numbers in this assay, from the lowest: compound 3; then compound 4; then compound 1; then compound 2.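

In this assay, a single added chain carbon on the aromatic nitrogen already counts: a 2.4-fold lower number from compound 1 to compound 4 (0.39 log units; beyond the scatter) is a modest step beyond the scatter. Ethyl also recovers part of what the dimethylamino-bearing chain costs, with a 5.7-fold lower number from compound 2 to compound 4 (0.76 log units; beyond the scatter) as the step, but it does not match the large group, since an 8.8-fold higher number from compound 3 to compound 4 (0.94 log units; beyond the scatter) remains. No measured evidence bears on the reason for these steps.

Still open, on these data alone, is whether propyl or cyclohexyl on that nitrogen would give a number closer to that of compound 3 or compound 4.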